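The source may report more compounds than this note shows. Statements on the series, on what has been measured and on what is new or still open speak of the compounds shown alone.

Working notes on the series. In a functional assay on SGC-7901 cells (Homo sapiens) for antiproliferative activity, read by MTT assay, with a stated time of 24 h (on this read-out higher numbers stand for weaker inhibition and lower numbers for stronger inhibition), compound 1 `O=c1[nH]cc(S(=O)(=O)Nc2cccc(-c3cn(-c4ccccc4F)nn3)c2)c(=O)[nH]1` gives 16000 nM, compound 2 `O=c1[nH]cc(S(=O)(=O)Nc2cccc(-c3cn(-c4ccccc4Cl)nn3)c2)c(=O)[nH]1` gives 3010 nM, and compound 3 `O=c1[nH]cc(S(=O)(=O)Nc2ccc(-c3cn(-c4ccccc4)nn3)cc2)c(=O)[nH]1` gives 18800 nM, the highest of the three numbers shown, though its gap to compound 1 lies within the scatter while compound 2 sits clearly lower. Compound 4 `O=c1[nH]cc(S(=O)(=O)Nc2ccc(-c3cn(-c4cccc(Cl)c4)nn3)cc2)c(=O)[nH]1` differs from compound 3 by chloro in place of hydrogen on an aromatic carbon, phenyl to 3-chlorophenyl. Among the compounds with values here, the only measured step involving a chloro is a 5.3-fold lower number from compound 1 to compound 2 (0.73 log units; beyond the scatter), where chloro replaces fluoro rather than hydrogen, so it bears on this change only loosely. A modest lowering of the number is therefore expected, about a 2.4-fold lower number from compound 3 to compound 4 (0.37 log units; beyond the scatter). Compound 4 is estimated at 8000 nM, within 3000 nM to 22000 nM.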

Compound 4, half-maximal inhibitory concentration: 2460 nM
Beside the measured number, compound 4's estimate is 3.3-fold (0.51 log units) above it, and the stated range ends above it.
By their numbers in this assay, from the lowest: compounds 4 and 2 (each within the scatter of the next); then compounds 1 and 3 (each within the scatter of the next).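

In this assay, chloro in place of hydrogen, meta to a large group, gives a 7.6-fold lower number from compound 3 to compound 4 (0.88 log units; beyond the scatter), so the number falls on the core of compound 3 when chloro replaces hydrogen, a change the earlier step, with chloro replacing fluoro, did not test. No data bearing on the reason for this fall are available. As far as these compounds go, whether a methyl, methoxy or trifluoromethyl group at this place would lower the number as chloro does remains open. So does the effect of this 3-chlorophenyl group on the core of compound 1.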